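The source may report more compounds than this note shows. Statements on the series, on what has been measured and on what is new or still open speak of the compounds shown alone.

Measured compounds:
- compound 1, `Oc1cccc(/C=C2\CCCN=C2c2cccnc2)c1`: in an assay on membranes from brain for displacement of a labelled ligand from Neuronal acetylcholine receptor; alpha4/beta2 (Rattus norvegicus), with a stated time of 3 h (a lower number here means a stronger inhibitor, a higher number a weaker inhibitor), compound 1 gives 1170 nM
- compound 2, `FC(F)Oc1ccc(/C=C2\CCCN=C2c2cccnc2)cc1`: in this assay compound 2 gives 1160 nM

Among the measured compounds shown here, compound 2 holds the lower of the two numbers known in this assay, but compound 1 sits so close to it that the two cannot be told apart. Compound 3, `CC(C)(C)C(=O)Oc1ccc(/C=C2\CCCN=C2c2cccnc2)cc1`, shares the core of these two and differs from compound 2 in one place: (tert-butyl)carbonyl in place of difluoromethyl on an oxygen on an aromatic ring. For the measured compounds named here, both known compounds, the one carrying a bare hydroxyl and the one carrying difluoromethoxy, give practically the same reading, so the numbers give no step to lean on for this change. The group that enters is larger than the one that leaves, and the expectation is a step from compound 2 to compound 3 of a 1.4-fold higher number from compound 2 to compound 3 (0.14 log units; within the scatter) in this assay, towards a weaker inhibitor, but modest. Compound 3 is therefore expected to give about 1600 nM in this assay, within a range from 500 nM to 5000 nM.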

Compound 3, inhibition constant: 830 nM
For compound 3 the middle estimate is 1.9-fold (0.29 log units) above the measured one; measured number inside the range.
By their numbers in this assay, from the lowest: compounds 3, 2 and 1 (each within the scatter of the next).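

On an oxygen on an aromatic ring, difluoromethyl can give way to the larger (tert-butyl)carbonyl with no readable change in this assay, the step being a 1.4-fold lower number from compound 2 to compound 3 (0.15 log units; within the scatter). Among the compounds shown here, this is the first direct comparison at this position, and it shows that adding a carbonyl and a bulkier tert-butyl end leaves the reading within the scatter, so this change does not cost measurable affinity. No other measurement bears on this result.

As far as these compounds go, with only these two groups compared on this oxygen, it remains open whether any group placed there can move the number beyond the scatter in either direction. An amine, a carboxylic acid or a longer alkyl chain at the same place would test this.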